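This account rests on a few compounds, and the source may have more. Where it says the series, first, only, none or still open, it means among the compounds named here.

In a functional assay on SK-OV-3 cells (Homo sapiens) for antiproliferative activity, read by MTT assay, with a stated time of 72 h (a higher number here means a weaker inhibitor, a lower number a stronger inhibitor), compound 1 `O=C(CCc1cccc2c1B(O)OC2)Nc1ccccc1` gives 200 nM and compound 2 `O=C(CCc1cccc2c1B(O)OC2)Nc1ccc(F)cc1` gives 720 nM as the higher of the two numbers, so compound 2 is the weaker inhibitor of the pair. Compound 3 `O=C(CCc1cccc2c1B(O)OC2)Nc1ccc(Cl)cc1` differs from compound 2 by chloro in place of fluoro on an aromatic carbon in one place, with chloro in place of fluoro on an aromatic carbon. Going by the values given here, the only measured step that bears on this is a 3.6-fold higher number from compound 1 to compound 2 (0.56 log units; beyond the scatter) for fluoro in place of hydrogen, a modest step that shows nothing directly about chloro. No step beyond the scatter is therefore expected in this assay, with a slight lean towards a lower number. The change estimated here is small (a 1.4-fold lower number from compound 2 to compound 3 (0.16 log units; within the scatter)). For compound 3 the expected value is 500 nM with an estimated range from 180 nM to 1400 nM in this measurement.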

Compound 3, half-maximal inhibitory concentration: 5000 nM
Beside the measured number, compound 3's estimate is 10-fold (1.00 log units) below it, and the stated range ends below it.
By their numbers in this assay, from the lowest: compound 1; then compound 2; then compound 3.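

At this position, para to a large group, the choice of halogen matters: in this assay, chloro in place of fluoro gives a 6.9-fold higher number from compound 2 to compound 3 (0.84 log units; beyond the scatter). Chloro in place of hydrogen gives a 25-fold higher number from compound 1 to compound 3 (1.40 log units; beyond the scatter), a larger step than the one for fluoro, a 3.6-fold higher number from compound 1 to compound 2 (0.56 log units; beyond the scatter). Both halogens here therefore go with a weaker inhibitor than hydrogen, chloro more so.

The data shown give no cause for these rises. As far as these compounds go, whether bromo would raise the number further, and how a methoxy group or an amine would behave at this position, remains open.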